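Working notes: hydroxy to hydrogen on the aryl ring of compound 1

The compounds below may be only part of what the source reports. "The series", "measured", "known", "first", "only" and "open" are said of these compounds alone.

Measured so far:
- compound 1, `O=C(/C=C(O)/C=C/c1ccc(O)cc1O)c1ccccc1O`: 61.2%
- compound 2, `O=C(/C=C(O)/C=C/c1cc(O)ccc1O)c1ccc(O)cc1O`: 86.6%
- compound 3, `O=C(C1=C(O)/C(=C/c2ccc(O)cc2)CCC1)c1ccccc1`: 34.9%

In an assay on isolated protein for inhibition of Alpha glucosidase (Homo sapiens), with stated times of 5 min and 15 min, tested at 50 uM (on this read-out lower numbers stand for less inhibition and higher numbers for more inhibition at the one concentration tested (going by the name of the read-out)), compound 1 gives 61.2% and stands second highest of the three numbers. Within the data shown here, compound 2 sits above it, beyond the scatter, and compound 3 sits below it, also beyond the scatter; no single-point step between any two of these three compounds is defined, so only the values themselves are available for comparison.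

Compound 4, `O=C(/C=C(O)/C=C/c1ccc(O)cc1)c1ccccc1O`, has not yet been measured in this assay. Relative to compound 1 it differs as follows: hydrogen in place of hydroxy on an aromatic carbon. The change sits on an aromatic carbon of a six-membered aromatic ring of carbon only, ortho to a large group.

Among the measured compounds shown here, with no comparable step among the measured compounds, the size of the move has to be judged from the values alone. The two compounds carrying more hydroxy groups than compound 3 return the higher numbers, but that is three points, not a rule. A modest fall from compound 1 is expected, a number 11.2 percentage points lower from compound 1 to compound 4 (beyond the scatter), of about the size of the scatter or a little beyond. Compound 4 is therefore estimated at 50%, within 35% to 65%.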

Compound 4, a percentage reported as inhibition, at one concentration (the size of the read-out at that concentration, not a potency): 20.4%
Compound 4: middle estimate off by 29.6 percentage points, on the high side; measured number outside the range, below it.
By their numbers in this assay, from the lowest: compound 4; then compound 3; then compound 1; then compound 2.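

In this assay, among these compounds, hydrogen in place of hydroxy on the aromatic carbon ortho to a large group gives a number 40.8 percentage points lower from compound 1 to compound 4 (beyond the scatter) and this is the first step that can be read at a single place. It shows that the outcome at the one concentration tested is sensitive to this one hydroxy, even with a hydroxy group remaining meta to the changed carbon, which the three earlier compounds could not show because none of them differs from another in only one place. Nothing on hand gives a measured reason for the size of this fall.

The compounds shown compare only hydroxy and hydrogen at this aromatic carbon, so it remains open whether a methoxy group, an amine or a fluorine atom there would keep the number nearer to that of the hydroxy compound or leave it nearer to that of the hydrogen compound. On these data alone, it also remains open whether removing a hydroxy group from any other aromatic carbon would produce a step of similar size.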